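Swapping the aryl group on a quinoline thiosemicarbazone

The compounds below may be only part of what the source reports. "The series", "measured", "known", "first", "only" and "open" are said of these compounds alone.

Measured compounds:
- compound 1, `COc1ccccc1NC(=S)N/N=C/c1ccc2ccccc2n1`: > 100000 nM
- compound 2, `NC(=S)N/N=C/c1ccc2cccnc2n1`: 12800 nM
- compound 3, `NC(=S)N/N=C/c1cc2ccccc2s1`: 99200 nM

Three thiosemicarbazones have been tested in a functional assay on HT-29 cells (Homo sapiens) for antiproliferative activity, read by sulforhodamine B assay, with a stated time of 72 h; a higher number here means a weaker inhibitor, a lower number a stronger inhibitor. Compound 1 gives only a limit in this assay, > 100000 nM, so its true value is not known as a number. Compound 2 gives 12800 nM in this assay, and compound 3 gives 99200 nM. Compound 1 therefore sits at the weak end of what has been seen so far, as the one that sits at the limit (the limit of > 100000 nM in this assay, at which 1 of the 3 values shown sits).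

Compound 4, `Fc1ccc(NC(=S)N/N=C/c2ccc3ccccc3n2)cc1`, is not yet measured. It differs from compound 1 in one place: 4-fluorophenyl in place of 2-methoxyphenyl on an amide-type nitrogen. Within the data shown here, no pair of measured compounds differing in one place is available to calibrate this change, so the expectation rests only on where compound 1 stands and on the spread of the other two values.

Compound 4 is expected to remain a weak inhibitor in this assay, with an estimated value of 70000 nM, between 15000 nM and 200000 nM. The expected step of an at least 1.4-fold lower number from compound 1 to compound 4 (0.15 log units; that floor lies within the scatter) is uncertain in size and direction, since compound 1 is known only as a limit.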

Compound 4, half-maximal inhibitory concentration: 28500 nM
For compound 4 the middle estimate is 2.5-fold (0.39 log units) above the measured one; the measured number falls inside the stated range.
By their numbers in this assay, from the lowest: compound 2; then compound 4; then compound 3. At a limit, above all of these: compound 1.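

On the amide-type nitrogen of the shared core, the choice of aryl group clearly matters in this assay: 4-fluorophenyl in place of 2-methoxyphenyl gives an at least 3.5-fold lower number from compound 1 to compound 4 (0.54 log units; beyond the scatter). Compound 4 also shows that an aryl group on this nitrogen can give a measured number, which compound 1 alone could not show. Compound 1 is known only as a limit, so the true size of the step stays unknown and the printed size is only a floor: the limit of > 100000 nM in this assay, at which 1 of the 4 values shown sits.

From the compounds shown here alone, the two aryl groups differ in both their substituent and its ring position, so it remains open whether losing the 2-methoxyphenyl group or adding the 4-fluorophenyl group drives the change. Also open, going by these compounds, is how an unsubstituted phenyl, a phenyl carrying an amine or a carboxylic acid, or a longer alkyl chain would behave on this nitrogen.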